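Methoxy to ethoxy on a shared core: expected effect

A few compounds are considered here, and "the series" means these few. Any claim that something is new, unique, unknown or untested is made for them only; others in the source may bear on it.

Compound 1 `CCOc1nc(-c2cc3ccccc3o2)cc(-c2ccccc2)c1C#N`: 310000 nM
Compound 2 `COc1nc(-c2cc3ccccc3o2)cc(-c2cn(C)c3ccccc23)c1C#N`: 262000 nM

Of the compounds shown here, two have been measured in a functional assay on aorta (strain Wistar) for inhibition, with Thoracic aorta (Rattus norvegicus) as the target; on this read-out higher numbers stand for weaker inhibition and lower numbers for stronger inhibition. Compound 1 `CCOc1nc(-c2cc3ccccc3o2)cc(-c2ccccc2)c1C#N` gives 310000 nM in this assay. Compound 2 `COc1nc(-c2cc3ccccc3o2)cc(-c2cn(C)c3ccccc23)c1C#N` gives 262000 nM in this assay. The two numbers lie within the usual scatter of each other, so the data do not tell the two compounds apart; both are weak inhibitors on this read-out.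

Compound 3 `CCOc1nc(-c2cc3ccccc3o2)cc(-c2cn(C)c3ccccc23)c1C#N` has not been measured. It differs from compound 2 in one place: methyl in place of hydrogen on a saturated chain carbon bound to an oxygen on an aromatic ring, which turns the methoxy group into an ethoxy group. Within the data shown here, no measured pair shows this exact change on its own, so no step size can be read off for it. Given that compound 1, which carries the ethoxy group, gives 310000 nM, a step from compound 2 to compound 3 of no size beyond the scatter is expected, namely a 1.0-fold lower number from compound 2 to compound 3 (0.02 log units; within the scatter). Compound 3 is therefore estimated at 250000 nM, with a range from 100000 nM to 600000 nM.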

Compound 3, half-maximal inhibitory concentration: 327000 nM
Estimate against measurement, compound 3: 1.3-fold (0.12 log units) below, and the stated range covers the measured number.
By their numbers in this assay, from the lowest: compounds 2, 1 and 3 (each within the scatter of the next).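

In this assay, the step from methoxy to ethoxy is now measured on its own and gives a 1.2-fold higher number from compound 2 to compound 3 (0.10 log units; within the scatter), so methyl in place of hydrogen at this place produces no difference that the assay can resolve. Compound 3 also provides a second single-place comparison, 1-methyl-1H-indol-3-yl in place of phenyl on an aromatic carbon, which gives a 1.1-fold higher number from compound 1 to compound 3 (0.02 log units; within the scatter) and so cannot be told apart from the scatter either; compound 1 and compound 2 differ in two places, so their pair could not isolate either change. Nothing measured here explains why these two steps fall within the scatter.

As far as these compounds go, whether a longer chain such as propoxy, or an amine in place of the ethoxy group, would shift the number beyond the scatter remains open. From the compounds shown here alone, it is also open whether the change from methoxy to ethoxy would behave the same way on the core of compound 1, which carries phenyl rather than 1-methyl-1H-indol-3-yl.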